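The source may report more compounds than this note shows. Statements on the series, on what has been measured and on what is new or still open speak of the compounds shown alone.

Compound 1, `O=C(O)c1cccc(-n2c(-c3ccccc3)cc3c2CCCC3)c1`: 20%
Compound 2, `O=C(O)c1cc(-n2c(-c3ccccc3)cc3c2CCCC3)ccc1Cl`: 40%
Compound 3, `O=C(O)c1cc(-n2c(-c3ccc(Cl)cc3)cc3c2CCCC3)ccc1O`: 40%

All three were examined in a functional assay on the whole organism (strain Wistar) for inhibition, with Rattus norvegicus as the target, read by paw edema, with stated times of 30 min and 3 h, at a dose of 200 mg/kg by the oral route; on this read-out lower numbers stand for less inhibition and higher numbers for more inhibition at the one dose given (going by the name of the read-out). Going by the values given here, the only change of a single place between measured compounds is chloro in place of hydrogen on an aromatic carbon, and it brought a number 20 percentage points higher from compound 1 to compound 2 (beyond the scatter). Compound 3 differs from compound 1 in more than one place, and that difference between the two cores is not broken down here. The values of compound 3 and compound 2 are level at the digits given, within the scatter, so no order between them can be read.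

Compound 4, `O=C(O)c1cc(-n2c(-c3ccc(Cl)c(Cl)c3)cc3c2CCCC3)ccc1O`, has yet to be tested in this assay. Against compound 3 it shows (chloro in place of hydrogen on an aromatic carbon). This is the same kind of change as that from compound 1 to compound 2, but not the same: there the entering chloro stood ortho to a carboxy group and para to a large group, here it stands ortho to a chloro group and meta to a large group. Because the earlier step read a number 20 percentage points higher from compound 1 to compound 2 (beyond the scatter), a step of a number 10 percentage points higher from compound 3 to compound 4 (within the scatter) is expected, held modest since the surroundings differ. Compound 4 is therefore estimated at 50%, between 30% and 70%.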

Compound 4, a percentage reported as inhibition, in the whole organism at one dose (the size of the read-out at that dose, not a potency): 0%
Compound 4: the middle estimate sits 50 percentage points above what was measured; measured number below the stated range.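

In this assay, the same replacement of hydrogen by chloro on an aromatic carbon gave a number 40 percentage points lower from compound 3 to compound 4 (beyond the scatter) and did not repeat the earlier gain of a number 20 percentage points higher from compound 1 to compound 2 (beyond the scatter), so the size and direction of this step did not carry from one core to the other: the same change on two cores in this assay, a number 20 percentage points higher (beyond the scatter) from compound 1 to compound 2 and a number 40 percentage points lower (beyond the scatter) from compound 3 to compound 4, 60 percentage points apart, beyond the scatter of two such steps. For these two pairs, a gain on one core therefore gave no safe guide to the result on another. The two pairs do not show what sets the steps apart, as the entering chloro stands in a different place in each pair and the cores also differ, and two pairs give no general rule for the series.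

The compounds shown leave open whether fluoro, methyl or methoxy in the place of this second chloro would give a similar fall. They also leave open how the 4-chlorophenyl to 3,4-dichlorophenyl change would read on the core of compound 2, where chloro takes the place of the hydroxy group.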